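A few compounds are considered here, and "the series" means these few. Any claim that something is new, unique, unknown or untested is made for them only; others in the source may bear on it.

Compound 1 `COC(=O)COc1ccc(OCc2ccc3ccccc3n2)cc1C1(c2ccccc2)CC2CCC1C2`: 290 nM
Compound 2 `Oc1ccc(OCc2ccc3ccccc3n2)cc1C1(c2ccccc2)CCCC1`: 1920 nM

In a functional assay on blood (Homo sapiens) for inhibition (on this read-out higher numbers stand for weaker inhibition and lower numbers for stronger inhibition), compound 2 gives 1920 nM. This is the higher of the two numbers and therefore the weaker inhibition, and its gap to compound 1 lies beyond the scatter.

Compound 3 `c1ccc(C2(c3cc(OCc4ccc5ccccc5n4)ccc3OCc3ccc4ccccc4n3)CCCC2)cc1` follows from compound 2 through one change: (quinolin-2-yl)methyl in place of hydrogen on an oxygen on an aromatic ring. Put simply, hydroxy gives way to (quinolin-2-yl)methoxy, with (quinolin-2-yl)methyl in place of hydrogen on an oxygen on an aromatic ring.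

Going by the values given here, no measured pair isolates this change, so the evidence is thin. Compound 1, at 290 nM, also has no free hydroxy group, but it differs from compound 2 in other parts of the structure as well, so it offers only a loose hint. A moderate move toward a lower number in this assay is therefore expected, and it may not clear the scatter by much. The estimated change is a 2.1-fold lower number from compound 2 to compound 3 (0.33 log units; beyond the scatter). Compound 3 is expected at 900 nM, with an estimated range of 250 nM to 3200 nM.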

Compound 3, half-maximal inhibitory concentration: 1080 nM
Compound 3: middle estimate off by 1.2-fold (0.08 log units), on the low side; low and high end bracket the measured number.
By their numbers in this assay, from the lowest: compound 1; then compounds 3 and 2 (each within the scatter of the next).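

In this assay, going by these compounds alone, replacing hydroxy with (quinolin-2-yl)methoxy on the aromatic ring gives a 1.8-fold lower number from compound 2 to compound 3 (0.25 log units; within the scatter) and so provides the first direct reading of this position. The oxygen can therefore carry (quinolin-2-yl)methyl, a group of 11 heavy atoms with two aromatic rings, in place of hydrogen without a difference that stands out from the scatter, and a free hydroxy at this place is not needed to hold inhibition at the level of compound 2. No measured property is at hand to account for this outcome.

From the compounds shown here alone, it remains open whether a different group on this oxygen, such as a carboxylic acid, an amine or a longer chain, would shift the number beyond the scatter, since one substituent tells little about the position as a whole. Compound 1 differs from compound 2 and compound 3 in more than one place, so the contribution of its oxygen substituent cannot be separated from that of the rest of its core.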